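The source may report more compounds than this note shows. Statements on the series, on what has been measured and on what is new or still open speak of the compounds shown alone.

Compound 1 `CCCCCCc1ccc(-c2ccc(C(=O)N[C@@H](CCCN)C(=O)N[C@H](C(=O)N[C@@H](C)C(=O)N[C@H]3Cc4cn(nn4)CCO[C@@H]4C[C@@H]5OB(O[C@@H]5C4)[C@H](C)NC3=O)[C@@H](C)O)cc2)cc1` is a large ring-closed peptide carrying a boron-containing ring and a 4-hexylphenyl group at one end. In an ADME assay on HepG2 cells (Homo sapiens) for cytotoxicity, with a stated time of 72 h (a lower number here means a stronger inhibitor, a higher number a weaker inhibitor), compound 1 gives 8000 nM. Compound 3 `CCCCCCc1ccc(-n2cc(C(=O)N[C@@H](CCCN)C(=O)N[C@H](C(=O)N[C@@H](C)C(=O)N[C@H]3Cc4cn(nn4)CCO[C@@H]4C[C@@H]5OB(O[C@@H]5C4)[C@H](C)NC3=O)[C@@H](C)O)ccc2=O)cc1` carries the same hexyl-bearing ring on a different core; the difference between the two cores is not broken down here. In this assay compound 3 reaches only the limit > 64000 nM. Compound 2 `C[C@@H]1NC(=O)[C@@H](NC(=O)[C@H](C)NC(=O)[C@@H](NC(=O)[C@H](CCCN)NC(=O)c2ccc(=O)n(-c3ccccc3)c2)[C@@H](C)O)Cc2cn(nn2)CCO[C@@H]2C[C@@H]3OB1O[C@@H]3C2` is compound 3 with hydrogen in place of hexyl on an aromatic carbon. In this assay compound 2 also reaches only the limit > 64000 nM, so the step that the two limits leave unreadable from compound 3 to compound 2 cannot be read. Compound 4 `C[C@@H]1NC(=O)[C@@H](NC(=O)[C@H](C)NC(=O)[C@@H](NC(=O)[C@H](CCCN)NC(=O)c2ccc(-c3ccccc3)cc2)[C@@H](C)O)Cc2cn(nn2)CCO[C@@H]2C[C@@H]3OB1O[C@@H]3C2` is compound 1 with the same change, (hydrogen in place of hexyl on an aromatic carbon). Since both hexyl-free compounds sit at the limit of > 64000 nM in this assay, at which 2 of the 3 values shown sit, compound 4 is expected to weaken by a 5.0-fold higher number from compound 1 to compound 4 (0.70 log units; beyond the scatter). Compound 4 is therefore estimated at 40000 nM, quite possibly reported only as a limit.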

Compound 4, half-maximal inhibitory concentration: > 64000 nM
Compound 4: a limit, no number (the forecaster's own chance of this, stated with the estimate: 55%); at least 1.6-fold (0.20 log units) between middle value and limit.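

In this assay, going from 4-hexylphenyl to phenyl gives an at least 8.0-fold higher number from compound 1 to compound 4 (0.90 log units; beyond the scatter), so on the core of compound 1 the hexyl group goes with the lower number, and the true size of the step could be larger. On the core of compound 3 the same change cannot be read, since compound 3 and compound 2 both stand at a limit rather than at a number. Whether the change carries from one core to the other therefore stays unshown, and little in the set can be measured against: the limit of > 64000 nM in this assay, at which 3 of the 4 values shown sit.

Still open, as far as these compounds go, is where in this assay a butyl chain in place of hexyl would fall. The same holds for a hexyl chain carrying an amine.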